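Fluoro for Chloro: Expected Effect on Cell Cytotoxicity

This account rests on a few compounds, and the source may have more. Where it says the series, first, only, none or still open, it means among the compounds named here.

Compound 1 `CC(O)(CSc1ccc(Cl)cc1)c1nc(-c2ccc(F)c(Cl)c2)no1` is the weaker of the two compounds measured in a functional assay on LNCaP cells (Homo sapiens) for cytotoxicity, read by MTT assay (a higher number here means a weaker inhibitor, a lower number a stronger inhibitor), where compound 1 gives 26400 nM. Compound 2 `CC(O)(CSc1ccc(F)cc1)c1nc(-c2ccc([N+](=O)[O-])c(C(F)(F)F)c2)no1` gives 8150 nM in this assay, a gap beyond the usual scatter. Compound 3 `CC(O)(CSc1ccc(F)cc1)c1nc(-c2ccc(F)c(Cl)c2)no1` is not yet measured; it differs from compound 1 by fluoro in place of chloro on an aromatic carbon. Among the measured compounds shown here, no measured pair shows this exact exchange, so the step expected here is a 1.2-fold lower number from compound 1 to compound 3 (0.08 log units; within the scatter), most likely no larger than the scatter in either direction. Compound 3 is therefore estimated at 22000 nM, within a range from 8000 nM to 60000 nM.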

Compound 3, half-maximal inhibitory concentration: > 100000 nM
Compound 3 was reported as a limit; the forecaster's own chance of this, stated with the estimate: 10%; middle value at least 4.5-fold (0.65 log units) from the limit.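

In this assay, fluoro in place of chloro at this position is not a neutral exchange: the change gives an at least 3.7-fold higher number from compound 1 to compound 3 (0.57 log units; beyond the scatter). Going by these compounds, compound 3 is reported only as a limit of the assay, not as a number: the limit of > 100000 nM in this assay, at which 1 of the 3 values shown sits. With the rest of compound 1 unchanged, the chloro on this aromatic carbon clearly matters for this read-out, and the true size of the step remains unknown.

Whether a larger or different group would serve as well is open, as no bromo, methyl or methoxy group appears here. A 4-chlorophenyl partner for compound 2 would show whether the step carries over to another compound.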